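A few compounds are considered here, and "the series" means these few. Any claim that something is new, unique, unknown or untested is made for them only; others in the source may bear on it.

Compound 1, with structure `COc1cc(-c2cc(/C=C/C(=O)c3ccc(N)cc3)[nH]n2)cc(OC)c1OC`, gives 1400 nM in a functional assay on OVCAR-4 cells (Homo sapiens) for inhibition, read by sulforhodamine B assay, with a stated time of 48 h; a higher number here means a weaker inhibitor of growth, a lower number a stronger inhibitor of growth; that is the highest of the three numbers recorded so far. Its nearest neighbour is compound 3, `COc1ccc(-c2cc(/C=C/C(=O)c3ccc(N)cc3)[nH]n2)cc1`, which gives 1080 nM in this assay, a gap within the scatter. Furthest away is compound 2, `COc1ccc(-c2cc(/C=C/C(=O)c3ccc(OC)c(OC)c3)[nH]n2)cc1`, which gives 590 nM in this assay, a gap beyond the scatter. Compound 4, `COc1ccc(C(=O)/C=C/c2cc(-c3cc(OC)c(OC)c(OC)c3)n[nH]2)cc1OC`, has not yet been measured. It differs from compound 1 in one place: 3,4-dimethoxyphenyl in place of 4-aminophenyl on a carbonyl carbon. The values of compound 3 and compound 2 show that a 4-aminophenyl-bearing compound and a 3,4-dimethoxyphenyl-bearing compound with the same remainder sit within the scatter of each other, the dimethoxy compound at the lower number. On that basis a modest step toward a lower number is expected here, a 1.9-fold lower number from compound 1 to compound 4 (0.27 log units; within the scatter), though it may not clear the scatter. Compound 4 is therefore estimated at 750 nM in this assay, with a likely range from 350 nM to 1600 nM.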

Compound 4, concentration for 50% growth inhibition: 2690 nM
For compound 4 the middle estimate is 3.6-fold (0.55 log units) below the measured one, outside the stated range (above it).
By their numbers in this assay, from the lowest: compounds 2, 3, 1 and 4 (each within the scatter of the next, the first and the last beyond it).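

In this assay, the exchange of 4-aminophenyl for 3,4-dimethoxyphenyl on a carbonyl carbon gives a 1.9-fold higher number from compound 1 to compound 4 (0.28 log units; within the scatter), so on this remainder the position accepts the loss of the amine without a change that can be read. Compound 3 gives 1080 nM and compound 2 gives 590 nM, so the same exchange on a second remainder also stays within the scatter, and the two pairs together give it no direction of its own. No measurement at hand bears on why the exchange behaves this way.

The compounds shown leave open whether an unsubstituted phenyl or a 4-hydroxyphenyl on the same carbonyl carbon would stay within the same span. They also leave open whether an acetamide in place of the free amine would move the number beyond the scatter.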